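Compound 2 to compound 3: cyclopropyl in place of ethyl

This account rests on a few compounds, and the source may have more. Where it says the series, first, only, none or still open, it means among the compounds named here.

In an ADME assay on Vero cells (Chlorocebus sabaeus) for cytotoxicity, read by CellTiter-Glo, with a stated time of 72 h (a lower number here means that less compound is tolerated, a higher number that more compound is tolerated), compound 1 (`[O-][n+]1nc(NC2CC2)[n+]([O-])c2ccccc21`) gives 21 ug/mL and compound 2 (`CCNc1n[n+]([O-])c2cc(F)ccc2[n+]1[O-]`) gives 4.6 ug/mL. Compound 2 holds the lower of the two numbers, and the gap between them lies beyond the scatter. Compound 3 (`[O-][n+]1nc(NC2CC2)[n+]([O-])c2ccc(F)cc21`) is not yet measured and carries cyclopropyl in place of ethyl on a nitrogen on an aromatic ring. For the measured compounds named here, no measured step isolates this change. Going by the values given here, the only other reading, compound 1 at 21 ug/mL, sits higher, so the expectation leans upward. The expected change is small and within the scatter: a 1.7-fold higher number from compound 2 to compound 3 (0.24 log units; within the scatter). For compound 3 the estimated value is 8 ug/mL, with an expected range of 3 ug/mL to 22 ug/mL.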

Compound 3, half-maximal cytotoxic concentration: 1.3 ug/mL
The estimate for compound 3 lay 6.2-fold (0.79 log units) above the measured number; the measured number lies below the stated range.
By their numbers in this assay, from the lowest: compound 3; then compound 2; then compound 1.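

In this assay, cyclopropyl in place of ethyl on a nitrogen on an aromatic ring gives a 3.5-fold lower number from compound 2 to compound 3 (0.55 log units; beyond the scatter), so this position responds to the change, with less compound tolerated. With cyclopropylamino held, fluoro in place of hydrogen on an aromatic carbon gives a 16-fold lower number from compound 1 to compound 3 (1.21 log units; beyond the scatter), also towards less compound tolerated. No supporting measurement bears on the reason for either step.

Open, going by these compounds, is how a longer chain such as butyl would read on that nitrogen. Also open, on these data alone, is how chloro would read in place of fluoro on the aromatic carbon.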